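Carbamoyl to benzoyl on a thioxo-piperazine enaminonitrile

This account rests on a few compounds, and the source may have more. Where it says the series, first, only, none or still open, it means among the compounds named here.

Measured compounds in a functional assay on MDA-MB-435 cells (Homo sapiens) for inhibition, read by sulforhodamine B assay, with a stated time of 48 h; a higher number here means a weaker inhibitor of growth, a lower number a stronger inhibitor of growth:
- compound 1 `N#C/C(=C\N1CCN(C(=O)c2ccco2)C1=S)C(N)=O`: 14600 nM
- compound 2 `O=CN1CCN(c2ccc(Cl)c(Cl)c2)C1=S`: 16600 nM
- compound 3 `O=CN1CCN(c2cc(Cl)cc(Cl)c2)C1=S`: 14200 nM

All three numbers sit close together. Compound 1 has the second highest of the three, with compound 3 nearest and compound 2 furthest, and both gaps fall within the usual scatter of this assay, so no order among the three can be claimed. Within the data shown here, compound 2 and compound 3 share a core with compound 1 but carry a dichlorophenyl group and a formyl group instead of the furoyl and enaminonitrile side chains, and no single-change step between any pair of the measured compounds is available.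

The unmeasured compound 4 `N#C/C(=C\N1CCN(C(=O)c2ccco2)C1=S)C(=O)c1ccccc1` differs from compound 1 in one place: phenyl in place of amino on a carbonyl carbon. Among the measured compounds shown here, no measured pair shows this kind of exchange, so there is nothing to anchor the size of the step. The step from compound 1 to compound 4 is therefore expected to be modest, a 1.8-fold lower number from compound 1 to compound 4 (0.26 log units; within the scatter), toward a lower number but not clearly beyond the scatter. Compound 4 is estimated at 8000 nM, within a range from 2000 nM to 30000 nM.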

Compound 4, concentration for 50% growth inhibition: 11000 nM
For compound 4 the middle estimate is 1.4-fold (0.14 log units) below the measured one, within the range that was stated.
By their numbers in this assay, from the lowest: compounds 4, 3, 1 and 2 (each within the scatter of the next).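

Among these compounds, this is the first single-change step in the set, and it falls on a carbonyl carbon whose other neighbour is a double-bonded chain carbon. In this assay phenyl in place of amino gives a 1.3-fold lower number from compound 1 to compound 4 (0.12 log units; within the scatter) and so cannot be told apart from no change, even though carbamoyl to benzoyl removes a hydrogen-bond donor and brings in a six-membered aromatic ring. At this position, then, a much larger group replaces the amino group without a readable shift in growth inhibition, and nothing available accounts for this result.

Still open, on these data alone, is whether a hydroxyl on this carbonyl carbon, which would give a carboxylic acid, or a dimethylamino group would move the number beyond the scatter. Also open, as far as these compounds go, is whether dichlorophenyl in place of phenyl on the same carbon would do so.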